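This account rests on a few compounds, and the source may have more. Where it says the series, first, only, none or still open, it means among the compounds named here.

In a functional assay on MHCC97H cells (Homo sapiens) for antiproliferative activity, read by MTT assay, with a stated time of 48 h (a higher number here means a weaker inhibitor, a lower number a stronger inhibitor), two compounds have been measured so far. Compound 1 `COc1ccc2c(/C=C/C(=O)c3cc(OC)c(OC)c(SC)c3)c[nH]c2c1` gives 112 nM, and compound 2 `COc1ccc2c(/C=C(\C)C(=O)c3cc(OC)c(OC)c([Se]C)c3)cn(C)c2c1` gives 15 nM, the lower of the two numbers and a gap beyond the usual scatter. These two compounds differ in more than one place, so their gap cannot be assigned to any single change. Compound 3 `COc1ccc2c(/C=C(\C)C(=O)c3cc(OC)c(OC)c([Se]C)c3)c[nH]c2c1` departs from compound 2 in one place only: hydrogen in place of methyl on an aromatic nitrogen. For the measured compounds named here, no measured pair isolates this change, so the data give no direct guide to its size. In this assay a small step is expected, probably within the scatter, with a slight rise the likelier direction. This expectation amounts to an estimated 1.7-fold higher number from compound 2 to compound 3 (0.22 log units; within the scatter). For compound 3 the expected value is 25 nM, with an estimated range from 8 nM to 80 nM.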

Compound 3, half-maximal inhibitory concentration: 6 nM
Estimate against measurement, compound 3: 4.2-fold (0.62 log units) above; the measured number lies below the stated range.
By their numbers in this assay, from the lowest: compound 3; then compound 2; then compound 1.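

In this assay, for the compounds shown here, hydrogen in place of methyl on the aromatic nitrogen gives a 2.5-fold lower number from compound 2 to compound 3 (0.40 log units; beyond the scatter), the first change at this position that can be read on its own. The step is modest but beyond the scatter, and it shows that the methyl on this nitrogen is not needed for activity in this pair, since the compound bearing hydrogen has the lower number. No measured evidence bearing on the reason for this step is available.

The compounds shown leave open how an ethyl group, a longer chain or an acetyl group on this nitrogen would compare with hydrogen and methyl. They also leave open whether the same step would appear on another core, such as that of compound 1, where this nitrogen already bears hydrogen.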